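Changing the benzamide ring: from compound 3 to compound 4

The compounds below may be only part of what the source reports. "The series", "measured", "known", "first", "only" and "open" are said of these compounds alone.

Measured compounds:
- compound 1 `CNc1nc(Nc2ccc(C)c(N)c2)ncc1C(=O)Nc1cc(NC(=O)c2cccc(C(F)(F)F)c2)ccc1C` gives 14 nM
- compound 2 `CNc1nc(Nc2ccc(C)c([N+](=O)[O-])c2)ncc1C(=O)Nc1cc(NC(=O)c2ccc(OC)c(OC)c2)ccc1C` gives 680 nM
- compound 3 `CNc1nc(Nc2ccc(C)c(N)c2)ncc1C(=O)Nc1cc(NC(=O)c2ccccc2OC)ccc1C` gives 1980 nM

All three were tested in a functional assay on K562 cells (Homo sapiens) for antiproliferative activity, read by CellTiter-Glo and CCK-8 assay, with a stated time of 72 h; on this read-out lower numbers stand for stronger inhibition of growth and higher numbers for weaker inhibition of growth. Compound 3 gives the highest number of the three, that is the weakest growth inhibition. Compound 2 stands nearest to it, while compound 1 lies far below. Among the compounds with values here, the only measured step that isolates a change at the carbonyl carbon is a 140-fold higher number from compound 1 to compound 3 (2.15 log units; beyond the scatter), which shows that swapping the aromatic ring on that carbonyl can move the number a great deal.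

Compound 4 `CNc1nc(Nc2ccc(C)c(N)c2)ncc1C(=O)Nc1cc(NC(=O)c2ccc(OC)c(OC)c2)ccc1C` is not yet measured. It differs from compound 3 in one place: 3,4-dimethoxyphenyl in place of 2-methoxyphenyl on a carbonyl carbon. Within the data shown here, no measured pair repeats exactly this swap. The nearest guide is compound 2, which carries the same 3,4-dimethoxyphenyl on the carbonyl but a nitro group where compound 4 has an amine; compound 2 gives 680 nM, well below compound 3. On that basis compound 4 is expected to give a lower number than compound 3, a step of a 4.0-fold lower number from compound 3 to compound 4 (0.60 log units; beyond the scatter), beyond the scatter but far smaller than the step from compound 1 to compound 3. The estimate for compound 4 is 500 nM, expected to fall between 150 nM and 1800 nM.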

Compound 4, concentration for 50% growth inhibition: 380 nM
The estimate for compound 4 lay 1.3-fold (0.12 log units) above the measured number; low and high end bracket the measured number.
By their numbers in this assay, from the lowest: compound 1; then compounds 4 and 2 (each within the scatter of the next); then compound 3.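

In this assay, the ring on this carbonyl has a graded effect rather than an all-or-nothing one: 3,4-dimethoxyphenyl in place of 2-methoxyphenyl gives a 5.2-fold lower number from compound 3 to compound 4 (0.72 log units; beyond the scatter), yet the same ring in place of 3-(trifluoromethyl)phenyl gives a 27-fold higher number from compound 1 to compound 4 (1.43 log units; beyond the scatter), so it wins back only part of the ground separating compound 3 from compound 1. At the other end of the molecule, amino in place of nitro on an aromatic carbon gives a 1.8-fold lower number from compound 2 to compound 4 (0.25 log units; within the scatter), so with 3,4-dimethoxyphenyl on the carbonyl, this pair shows no real difference between the two groups. Nothing available explains why these rings differ so much.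

Still open, on these data alone, is whether amino and nitro would also read alike with 3-(trifluoromethyl)phenyl on the carbonyl, and whether a hydroxyl or an acetamide could take the place of the amino group. As far as these compounds go, it is also open whether the trifluoromethyl group itself is needed for the low number of compound 1, which a phenyl ring carrying a chlorine or a nitrile in its place would test.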